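A few compounds are considered here, and "the series" means these few. Any claim that something is new, unique, unknown or untested is made for them only; others in the source may bear on it.

Measured so far in a functional assay on the whole organism with Rattus norvegicus as the target; on this read-out higher numbers stand for an effect only at larger amounts of compound and lower numbers for an effect already at smaller amounts:
Compound 1 `Cn1c(=N)sc2cc(OC(F)(F)F)ccc21` gives 5 mg/kg
Compound 2 `N=c1sc2cc(OC(F)(F)F)ccc2n1CCO` gives 8 mg/kg
Compound 3 `CS(=O)(=O)CCn1c(=N)sc2cc(OC(F)(F)F)ccc21` gives 1.8 mg/kg

On these numbers compound 3 stands lowest of the three: a 2.8-fold lower number from compound 1 to compound 3 (0.44 log units; beyond the scatter) and a 4.4-fold lower number from compound 2 to compound 3 (0.65 log units; beyond the scatter), both beyond the scatter, while a 1.6-fold higher number from compound 1 to compound 2 (0.20 log units; within the scatter), so compound 1 and compound 2 cannot be told apart.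

Compound 4 `CN(C)CCCn1c(=N)sc2cc(OC(F)(F)F)ccc21` has not yet been measured. It differs from compound 3 in one place: (dimethylamino)methyl in place of methylsulfonyl on a saturated chain carbon, two bonds along the chain from an aromatic nitrogen. Among the measured compounds shown here, two measured steps touch this place. The step from compound 2 to compound 3 exchanged one group there for another and moved the number by a modest amount; the step from compound 1 to compound 3 added the whole side chain and also gave a modest shift. From the compounds shown here alone, nothing measured carries a (dimethylamino)methyl group, so its own effect is unknown. Since the two changes already seen at this place each shifted the number by a modest amount, a modest shift is expected here too, most plausibly back toward the numbers of compound 1 and compound 2. Compound 4 is therefore estimated at 4 mg/kg, within 1.5 mg/kg to 10 mg/kg. The expected step is a 2.2-fold higher number from compound 3 to compound 4 (0.35 log units; beyond the scatter).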

Compound 4, dose for half-maximal effect: 9 mg/kg
Estimate against measurement, compound 4: 2.3-fold (0.35 log units) below; low and high end bracket the measured number.
By their numbers in this assay, from the lowest: compound 3; then compounds 1, 2 and 4 (each within the scatter of the next).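

In this assay, putting (dimethylamino)methyl in place of methylsulfonyl at this place on the chain gives a 5.0-fold higher number from compound 3 to compound 4 (0.70 log units; beyond the scatter) even though both groups hold the same count of heavy atoms, so the low number of compound 3 does not carry over to this other end group. The new chain also brings no gain over the simpler side chains: the comparisons give a 1.1-fold higher number from compound 2 to compound 4 (0.05 log units; within the scatter) and a 1.8-fold higher number from compound 1 to compound 4 (0.26 log units; within the scatter), so among the four compounds only compound 3 stands apart. Nothing measured here gives a reason for this difference.

The compounds shown do not separate the effect of the end group from that of chain length. A longer chain ending in methylsulfonyl, a shorter chain ending in dimethylamino, or a chain ending in a carboxylic acid would test this.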